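A few compounds are considered here, and "the series" means these few. Any claim that something is new, unique, unknown or untested is made for them only; others in the source may bear on it.

Compound 1 `CC(C)(C)n1cc2c(n1)C(=O)CC1(CCN(C(=O)c3cc(-c4ccccc4Cl)nc4ccccc34)CC1)O2`: > 10000 nM
Compound 2 `CC(C)(C)n1cc2c(n1)C(=O)CC1(CCN(C(=O)c3cc(-c4ccc(Br)cc4)nc4ccccc34)CC1)O2`: > 10000 nM
Compound 3 `CC(C)(C)n1cc2c(n1)C(=O)CC1(CCN(C(=O)c3cc(-c4ccncc4)nc4ccccc34)CC1)O2`: not yet measured

In a functional assay on MDA-MB-231 cells (Homo sapiens) for inhibition, read by MTT assay, with a stated time of 72 h (a higher number here means a weaker inhibitor, a lower number a stronger inhibitor), compound 1 gives > 10000 nM, which is a limit of the assay and not a number. Compound 2 gives > 10000 nM, which is also a limit. Compound 2 therefore has no number of its own, and the limit of > 10000 nM in this assay, at which 2 of the 2 values shown sit, sums up the position. Compound 3 changes one group on the shared core: pyridin-4-yl in place of 4-bromophenyl on an aromatic carbon. This puts pyridin-4-yl in place of 4-bromophenyl on an aromatic carbon next to the ring nitrogen. Going by the values given here, one measured step bears on this change, at the same place: a step that the two limits leave unreadable from compound 1 to compound 2. Its size cannot be read. The expectation rests on compound 2 and its limit of > 10000 nM. No step beyond the scatter is expected in this assay, and another limit is the likeliest report. The estimated step is a step that the limit leaves unreadable from compound 2 to compound 3. The estimate for compound 3 is 12000 nM, with an expected range of 4000 nM to 30000 nM.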

Compound 3, half-maximal inhibitory concentration: 1650 nM
Compound 3: middle estimate off by 7.3-fold (0.86 log units), on the high side; measured number outside the range, below it.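

In this assay, this position turned out to respond to a change of group: pyridin-4-yl in place of 4-bromophenyl gives an at least 6.0-fold lower number from compound 2 to compound 3 (0.78 log units; beyond the scatter) and pyridin-4-yl in place of 2-chlorophenyl gives an at least 6.0-fold lower number from compound 1 to compound 3 (0.78 log units; beyond the scatter) as well. The two earlier groups, each a ring of carbon only, showed no such response, and the step between them cannot be read. Compound 3 is the only one of the three with a number of its own, while the other two compounds remain at a limit and not a number: the limit of > 10000 nM in this assay, at which 2 of the 3 values shown sit.

As far as these compounds go, whether the lower number depends on the ring nitrogen itself or on where it sits in the ring stays open. Also open, from the compounds shown here alone, is how a pyridin-3-yl group, or a phenyl ring carrying an amine or a carboxylic acid, would read at this position.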